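The source may hold more compounds than are shown below. What is called first, only, known or untested is meant among the compounds shown, and "the series" means these compounds.

Measured compounds:
compound 1, `Cn1ccc2cc(-c3ccc4oc(Nc5ccccc5)nc4c3)ccc21`: 48 nM
compound 2, `COc1cccc(-c2ccc3oc(N4Cc5ccccc5C4)nc3c2)c1`: 28 nM

Of the compounds shown here, two have been measured in an assay on HEK293 cells for inhibition of Fatty-acid amide hydrolase 1 (Homo sapiens), read by fluorescence (a higher number here means a weaker inhibitor, a lower number a stronger inhibitor), so far. In this assay compound 1 gives 48 nM and compound 2 gives 28 nM. Compound 2 has the lower of the two numbers, but its gap to compound 1 is within the usual scatter of this assay, so the two cannot be ranked against each other.

The next compound, compound 3, `COCc1ccc(-c2ccc3oc(N4Cc5ccccc5C4)nc3c2)cc1`, keeps the shared core of compound 2 and alters only the group on its aromatic carbon: 4-(methoxymethyl)phenyl in place of 3-methoxyphenyl on an aromatic carbon. Within the data shown here, no step between measured compounds of this kind is available, so the expectation rests on the measured pair alone. This change is expected to move the number little, if at all, beyond the scatter, perhaps slightly upward. Compound 3 is therefore expected to give about 45 nM in this assay, in a range from 15 nM to 150 nM. That estimate means a step of a 1.6-fold higher number from compound 2 to compound 3 (0.21 log units; within the scatter), expected to stay within the usual scatter.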

Compound 3, half-maximal inhibitory concentration: 10 nM
Estimate against measurement, compound 3: 4.5-fold (0.65 log units) above; measured number outside the range, below it.
By their numbers in this assay, from the lowest: compound 3; then compounds 2 and 1 (each within the scatter of the next).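

In this assay the aryl group on this aromatic carbon of the shared core proves able to shift the number: putting 4-(methoxymethyl)phenyl in place of 3-methoxyphenyl gives a 2.8-fold lower number from compound 2 to compound 3 (0.45 log units; beyond the scatter) and so a real gain in inhibition, though a modest one. The exchange alters two things at once, the place of the oxygen-bearing substituent on the phenyl ring and the chain that carries the oxygen, and this single step cannot separate the two. No measurement at hand explains the gain.

It remains open which of the two alterations accounts for the step, a question that 4-methoxyphenyl or 3-(methoxymethyl)phenyl at this position would address. Also open, as far as these compounds go, is whether a longer ether chain, or an amine in place of the methoxy group on the 4-methyl substituent, would lower the number further.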